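Propyl for Isopropyl on a Shared Amide

The source may hold more compounds than are shown below. What is called first, only, known or untested is meant among the compounds shown, and "the series" means these compounds.

Compound 1 `CCC1C(=O)N(C)c2cnc(-n3ccc4cc(C(=O)NC(C)C)ccc43)nc2N1c1ccn(C)n1` and compound 2 `CCCNC(=O)c1ccc2c(ccn2-c2ncc3c(n2)N(c2ccn(C)n2)C(CC)C(=O)N3C)c1` share one core, while compound 3 `CC[C@@H]1C(=O)N(C)c2cnc(-n3ccc4cc(C(=O)NC(C)C)ccc43)nc2N1C1CCCC1` carries another; the difference between the two cores is not broken down here. In a functional assay on K562 cells (Homo sapiens) for antiproliferative activity, read by CCK-8 assay, with a stated time of 72 h (a lower number here means a stronger inhibitor of growth, a higher number a weaker inhibitor of growth), compound 1 gives 8910 nM, and compound 2 gives 8270 nM; the step of a 1.1-fold lower number from compound 1 to compound 2 (0.03 log units; within the scatter) follows from propyl in place of isopropyl on an amide-type nitrogen. In this assay compound 3 gives 786 nM, the lowest of the three numbers and beyond the scatter from both others. Compound 4 `CCCNC(=O)c1ccc2c(ccn2-c2ncc3c(n2)N(C2CCCC2)[C@H](CC)C(=O)N3C)c1` differs from compound 3 by propyl in place of isopropyl on an amide-type nitrogen, the same change at a place described in the same words. Because the step of a 1.1-fold lower number from compound 1 to compound 2 (0.03 log units; within the scatter) stayed within the scatter, the corresponding step is expected to be small here as well, about a 1.0-fold lower number from compound 3 to compound 4 (0.02 log units; within the scatter). Compound 4 is therefore estimated at 750 nM, with an expected range from 350 nM to 1600 nM.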

Compound 4, concentration for 50% growth inhibition: 395 nM
Estimate against measurement, compound 4: 1.9-fold (0.28 log units) above; low and high end bracket the measured number.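

In this assay propyl in place of isopropyl on the amide-type nitrogen gives a step (a 2.0-fold lower number from compound 3 to compound 4 (0.30 log units; within the scatter)) that can be set directly beside the earlier one. On the two cores shown, the change gives steps that the data cannot tell apart: the same change on two cores in this assay, a 1.1-fold lower number (0.03 log units; within the scatter) from compound 1 to compound 2 and a 2.0-fold lower number (0.30 log units; within the scatter) from compound 3 to compound 4, 1.8-fold (0.27 log units) apart, within the scatter of two such steps. This shows that the change carried from one core to the other without a readable difference in this read-out, but it does not show that the same would hold on any further core, nor does it set propyl ahead of isopropyl.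

The compounds shown leave open whether a longer chain, a cyclopropyl group or a chain bearing an amine on this amide nitrogen would move the number beyond the scatter. They also leave open what a free carboxylic acid in place of the amide would do.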